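Pyrazolyl amide carried onto the ethoxy-substituted core

A few compounds are considered here, and "the series" means these few. Any claim that something is new, unique, unknown or untested is made for them only; others in the source may bear on it.

Two compounds have numbers in an assay on isolated protein for inhibition of cathepsin S (Homo sapiens), read by fluorescence; on this read-out lower numbers stand for stronger inhibition and higher numbers for weaker inhibition. Compound 2 `CCOc1ccc(C(=O)NC(C)C(=O)C(N)=O)c(Cl)c1C(F)(F)F` gives 11 nM. Compound 1 `CC(NC(=O)c1cccc(C(F)(F)F)c1Cl)C(=O)C(=O)Nc1cc[nH]n1` gives 14.1 nM, within the scatter of the number for compound 2. Compound 3 `CCOc1ccc(C(=O)NC(C)C(=O)C(=O)Nc2cc[nH]n2)c(Cl)c1C(F)(F)F` joins compound 2 with the amide end of compound 1; the change from compound 2 reads (1H-pyrazol-3-yl in place of hydrogen on an amide-type nitrogen). Within the data shown here, no step between measured compounds is at hand. Compound 1 already bears this group and gives 14.1 nM. No change beyond the scatter is therefore expected, a 1.1-fold higher number from compound 2 to compound 3 (0.04 log units; within the scatter). For compound 3 the estimate is 12 nM, with a range from 5 nM to 30 nM.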

Compound 3, half-maximal inhibitory concentration: 2.9 nM
Compound 3: middle estimate off by 4.1-fold (0.62 log units), on the high side; measured number below the stated range.
By their numbers in this assay, from the lowest: compound 3; then compounds 2 and 1 (each within the scatter of the next).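

In this assay on the ethoxy-bearing core, 1H-pyrazol-3-yl in place of hydrogen on the amide-type nitrogen gives a gain beyond the scatter (a 3.8-fold lower number from compound 2 to compound 3 (0.58 log units; beyond the scatter)). With that pyrazolyl amide in place, ethoxy in place of hydrogen on the aromatic carbon also gives a gain beyond the scatter (a 4.9-fold lower number from compound 1 to compound 3 (0.69 log units; beyond the scatter)). Among these compounds, compound 1 and compound 2 each carry only one of these groups and differ in two places, so neither step could be read before compound 3.

No measurement at hand accounts for these gains. From the compounds shown here alone, whether a methoxy or propoxy chain in place of ethoxy, or a phenyl ring in place of 1H-pyrazol-3-yl, keeps them remains open.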